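This account rests on a few compounds, and the source may have more. Where it says the series, first, only, none or still open, it means among the compounds named here.

In a functional assay on CAKI-1 cells (Homo sapiens) for antiproliferative activity (on this read-out lower numbers stand for stronger inhibition of growth and higher numbers for weaker inhibition of growth), two compounds have been measured so far. Compound 1 `Cc1ccnc2nc(-c3cccc(Cl)c3)cc(O)c12` gives 33.1 nM as its result, and compound 2 `Cc1cc(C)c2c(O)cc(-c3cccc(F)c3)nc2n1` gives 35.5 nM as its result. These two numbers lie within the usual scatter of repeated measurements, so compound 2 stands level with compound 1 and neither can be ranked above the other.

The next compound to be measured is compound 3 `Cc1cc(C)c2c(O)cc(-c3cccc(Cl)c3)nc2n1` and it differs from compound 2 in one place: chloro in place of fluoro on an aromatic carbon with chloro in place of fluoro on an aromatic carbon. Among the measured compounds shown here, no measured pair yet shows what such an exchange does, so any forecast rests on thin evidence. For the measured compounds named here, the starting point is compound 2 at 35.5 nM as measured, and with no step to guide the forecast, no change beyond the scatter is expected in this assay in either direction. The expected size of the move is a 1.1-fold lower number from compound 2 to compound 3 (0.05 log units; within the scatter) and this estimate stays within the scatter. For compound 3 the estimated value is 32 nM with an expected range from 12 nM to 85 nM on repeated measurement.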

Compound 3, concentration for 50% growth inhibition: 204 nM
The estimate for compound 3 lay 6.4-fold (0.80 log units) below the measured number; measured number outside the range, above it.
By their numbers in this assay, from the lowest: compounds 1 and 2 (each within the scatter of the next); then compound 3.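

In this assay, among the compounds shown here, chloro in place of fluoro on an aromatic carbon, meta to a large group, gives a 5.7-fold higher number from compound 2 to compound 3 (0.76 log units; beyond the scatter), so growth inhibition at this position depends on which halogen is present, even though only one atom changes. Methyl in place of hydrogen on an aromatic carbon, with the chloro kept, gives a 6.2-fold higher number from compound 1 to compound 3 (0.79 log units; beyond the scatter), so this second place on the core also affects the result. Taking either the chloro or the extra methyl away from compound 3 gives a lower number, which suggests that the two groups may matter in combination, although this reading rests on these three compounds alone.

The data available here give no explanation for the weaker growth inhibition of compound 3. Going by these compounds, it remains open whether a larger halogen such as bromo, or a methoxy group, would raise the number further at the chloro position, and whether an ethyl group in place of the extra methyl would do the same.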